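Compound 3 to compound 4: chloro in place of methyl

The compounds below may be only part of what the source reports. "The series", "measured", "known", "first", "only" and "open" are said of these compounds alone.

- compound 1 `O=C1/C(=C/c2ccc(-c3cnc4ccccc4c3)cc2)Oc2ccccc21` gives > 100000 nM
- compound 2 `O=C1/C(=C/c2cccc(-c3cnc4ccccc4c3)c2)Oc2ccccc21` gives > 100000 nM
- compound 3 `Cc1ccc(Oc2ccc(/C=C3\Oc4cc(O)ccc4C3=O)cc2)cc1` gives > 100000 nM

These readings come from an ADME assay on HEK293 cells (Homo sapiens) for cytotoxicity; a lower number here means that less compound is needed, a higher number that more compound is needed for the effect. Within the data shown here, the series so far shows only (the limit of > 100000 nM in this assay, at which 3 of the 3 values shown sit). Compound 3 stands at a limit (> 100000 nM), which is not a number.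

Compound 4 `O=C1/C(=C/c2ccc(Oc3ccc(Cl)cc3)cc2)Oc2cc(O)ccc21` carries chloro in place of methyl on an aromatic carbon, para to a large group (chloro in place of methyl on an aromatic carbon). Among the measured compounds shown here, no measured pair shows the size of such a change. No step beyond the scatter is expected in this assay, and the estimated change is a number no higher from compound 3 to compound 4 (the limit leaves the size open) without a favoured direction. The estimate for compound 4 is 100000 nM, with an expected range from 40000 nM to 200000 nM, and another limit reading is likely.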

Compound 4, half-maximal effective concentration: > 100000 nM
Compound 4: a limit, no number (the forecaster's own chance of this, stated with the estimate: 75%); the middle value lies on the limit itself.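

Compound 3 and compound 4 both give a limit and not a number, so no step can be read between them: the limit of > 100000 nM in this assay, at which 4 of the 4 values shown sit.

The compounds shown leave open whether chloro in place of methyl changes the reading at all, and which structure would give a number.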